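Chloro on the fused core of compound 2

A few compounds are considered here, and "the series" means these few. Any claim that something is new, unique, unknown or untested is made for them only; others in the source may bear on it.

Compound 3 `CCN(CC)CN1C(=O)/C(=N/NC(=S)Nc2ccccc2)c2ccccc21` gives 1600 nM in an ADME assay on MDCK cells (Canis lupus familiaris) for cytotoxicity; a lower number here means that less compound is tolerated, a higher number that more compound is tolerated. Compound 1 `CCN(CC)CN1C(=O)/C(=N/NC(=S)Nc2ccc(Cl)cc2)c2ccccc21` gives 400 nM in this assay, a step of a 4.0-fold lower number from compound 3 to compound 1 (0.60 log units; beyond the scatter) made by chloro in place of hydrogen on an aromatic carbon. Compound 2 `CCN(CC)CN1C(=O)/C(=N/NC(=S)Nc2ccc(OC)cc2)c2ccccc21` gives 9200 nM in this assay, the highest of the three, with a 23-fold higher number from compound 1 to compound 2 (1.36 log units; beyond the scatter) and a 5.8-fold lower number from compound 2 to compound 3 (0.76 log units; beyond the scatter); it differs from compound 3 by methoxy in place of hydrogen on an aromatic carbon.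

Compound 4 `CCN(CC)CN1C(=O)/C(=N/NC(=S)Nc2ccc(OC)cc2)c2cc(Cl)ccc21` is unmeasured and differs from compound 2 by chloro in place of hydrogen on an aromatic carbon. This is the same kind of change as from compound 3 to compound 1, chloro in place of hydrogen on an aromatic carbon, but the place differs: here the ring is part of a fused or bridged system of two rings, meta to a fused ring and para to a fused ring, rather than para to a large group. Among the compounds with values here, the earlier step of a 4.0-fold lower number from compound 3 to compound 1 (0.60 log units; beyond the scatter) is the only precedent; for compound 4 a somewhat smaller step, a 3.1-fold lower number from compound 2 to compound 4 (0.49 log units; beyond the scatter), is expected, with wide uncertainty. Compound 4 is estimated at 3000 nM in this assay, ranging from 800 nM to 12000 nM.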

Compound 4, half-maximal cytotoxic concentration: 11100 nM
For compound 4 the middle estimate is 3.7-fold (0.57 log units) below the measured one, within the range that was stated.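

On the core of compound 2, chloro in place of hydrogen on the fused ring system gives a 1.2-fold higher number from compound 2 to compound 4 (0.08 log units; within the scatter) in this assay, so no change can be claimed for this step. The two steps do not share the place of the chloro, and methoxy is present in compound 2 but absent from compound 3, so the data do not show which of these differences separates the steps. The size of this change therefore does not carry from one core to the other in this series: the same change on two cores in this assay, a 4.0-fold lower number (0.60 log units; beyond the scatter) from compound 3 to compound 1 and a 1.2-fold higher number (0.08 log units; within the scatter) from compound 2 to compound 4, 4.8-fold (0.68 log units) apart, beyond the scatter of two such steps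

On these data alone, it remains open how chloro at this fused-ring place behaves on the core of compound 3 without methoxy. Also open, as far as these compounds go, is whether bromo or nitrile at that place would track chloro.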